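Replacing Methoxy with 2-Chloro-6-fluorophenyl

The source may report more compounds than this note shows. Statements on the series, on what has been measured and on what is new or still open speak of the compounds shown alone.

Within the data shown here, compound 2 `COc1cc(-c2csc(NC(=O)C(=O)O)n2)on1` gives 1.2 mg/kg in a functional assay on the whole organism with Rattus norvegicus as the target (on this read-out higher numbers stand for an effect only at larger amounts of compound and lower numbers for an effect already at smaller amounts), the only actual number so far. Compound 1 `O=C(Nc1nc(-c2cc(-c3c(F)cccc3Cl)no2)cs1)C(=O)OCc1ccccc1` reaches only a limit, > 30 mg/kg. Compound 3 `O=C(O)C(=O)Nc1nc(-c2cc(-c3c(F)cccc3Cl)no2)cs1` differs from compound 2 by having 2-chloro-6-fluorophenyl in place of methoxy on an aromatic carbon of a five-membered aromatic ring with 1 nitrogen and 1 oxygen (2-chloro-6-fluorophenyl in place of methoxy on an aromatic carbon). Among the measured compounds shown here, no measured pair of compounds shows what this exchange does in this assay, so only a modest shift toward larger doses is expected, a 2.5-fold higher number from compound 2 to compound 3 (0.40 log units; beyond the scatter). Compound 3 is estimated at 3 mg/kg, with an expected range of 0.6 mg/kg to 20 mg/kg.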

Compound 3, dose for half-maximal effect: 2.4 mg/kg
Beside the measured number, compound 3's estimate is 1.3-fold (0.10 log units) above it, within the range that was stated.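

In this assay, the position on the aromatic carbon accepts 2-chloro-6-fluorophenyl, with 8 heavy atoms and a ring, as well as methoxy, with 2 heavy atoms: a 2.0-fold higher number from compound 2 to compound 3 (0.30 log units; within the scatter). The oxygen next to a carbonyl group is the more telling place, as hydrogen in place of benzyl gives an at least 12-fold lower number from compound 1 to compound 3 (1.09 log units; beyond the scatter). Compound 1 gives no number here, only a limit: the limit of > 30 mg/kg in this assay, at which 1 of the 3 values shown sits.

As far as these compounds go, what an amine or a plain phenyl would give on that aromatic carbon stays open. So does whether methyl in place of benzyl on that oxygen would give a similar step.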